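The source may report more compounds than this note shows. Statements on the series, on what has been measured and on what is new or still open speak of the compounds shown alone.

Among the compounds with values here, compound 1 `N=S1(=O)CC(Nc2nonc2/C(=N/O)Nc2ccc(F)c(Br)c2)C1` gives 53 nM in an assay on HeLa cells for inhibition of Indoleamine 2,3-dioxygenase 1 (Homo sapiens), read by spectrophotometry, with a stated time of 24 h (a higher number here means that more compound is needed for the effect, a lower number that less compound is needed), the highest of the three numbers measured so far, though the other two sit close to it: compound 2 `CCNS(=O)(=O)CCNc1nonc1/C(=N/O)Nc1ccc(F)c(Br)c1` gives 41 nM and compound 3 `C#CCNS(=O)(=O)CCNc1nonc1/C(=N/O)Nc1ccc(F)c(Br)c1` gives 33 nM. Compound 4 `NNS(=O)(=O)CCNc1nonc1/C(=N/O)Nc1ccc(F)c(Br)c1` is compound 1 with a single change: a group of 7 heavy atoms (2 carbon, 2 nitrogen, 2 oxygen, 1 sulfur; no ring) in place of a group of 6 heavy atoms (3 carbon, 1 nitrogen, 1 oxygen, 1 sulfur; one four-membered non-aromatic ring with 1 hetero atom), on a nitrogen on an aromatic ring. Within the data shown here, two measured steps bear on this, since each of them also replaced that four-membered ring with an open chain carrying a sulfonamide: a 1.3-fold lower number from compound 1 to compound 2 (0.11 log units; within the scatter) and a 1.6-fold lower number from compound 1 to compound 3 (0.21 log units; within the scatter). Both stayed within the scatter, so the step expected here is a 1.2-fold lower number from compound 1 to compound 4 (0.07 log units; within the scatter), a shift no larger than the scatter in either direction. Compound 4 is therefore estimated at 45 nM, with a likely range from 22 nM to 90 nM.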

Compound 4, half-maximal effective concentration: > 800 nM
Compound 4: a limit, no number; the forecaster's own chance of this, stated with the estimate: 2%; middle value at least 17-fold (1.24 log units) from the limit.
By their numbers in this assay, from the lowest: compounds 3, 2 and 1 (each within the scatter of the next). At a limit, above all of these: compound 4.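

Compound 4 gives only a limit of the assay, not a number: the limit of > 800 nM in this assay, at which 1 of the 4 values shown sits. Even so, an at least 15-fold higher number from compound 1 to compound 4 (1.17 log units; beyond the scatter) and an at least 19-fold higher number from compound 2 to compound 4 (1.29 log units; beyond the scatter) and an at least 24-fold higher number from compound 3 to compound 4 (1.38 log units; beyond the scatter) are all large steps. The open chain alone therefore does not set the number, since ethyl and propargyl on the sulfonamide nitrogen stay within the scatter of each other, while amino in that place does not stay near either.

The compounds shown leave open whether a methyl or a hydroxy group on that nitrogen would behave like ethyl or like amino. They also give no reason for the jump.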